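The source may report more compounds than this note shows. Statements on the series, on what has been measured and on what is new or still open speak of the compounds shown alone.

Of the compounds shown here, two that share one core have been measured in a functional assay on SF-295 cells (Homo sapiens) for inhibition, read by sulforhodamine B assay, with a stated time of 48 h; on this read-out lower numbers stand for stronger inhibition of growth and higher numbers for weaker inhibition of growth. Compound 1, with the structure `COc1ccc(-c2cc(/C=C/C(=O)c3ccc(N)cc3)[nH]n2)cc1`, gives 3090 nM in this assay. Compound 2, with the structure `COc1cc(-c2cc(/C=C/C(=O)c3ccc(N)cc3)[nH]n2)cc(OC)c1OC`, gives 2550 nM in this assay. Compound 2 thus has the lower of the two numbers, but the gap to compound 1 is within the scatter of repeated measurements, so the two cannot be told apart with confidence.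

Compound 3, with the structure `COc1ccc(-c2cc(/C=C/C(=O)c3ccc(N)cc3)[nH]n2)cc1OC`, has not yet been measured in this assay. It differs from compound 2 in one place: hydrogen in place of methoxy on an aromatic carbon. Put simply, hydrogen in place of methoxy on an aromatic carbon. Going by the values given here, no measured pair shows a step of this kind, so there is no direct guide to its size. Because compound 1 gives 3090 nM and compound 2 gives 2550 nM while carrying different numbers of methoxy groups, the loss of one methoxy group is expected to change little. The step is expected to be a 1.1-fold higher number from compound 2 to compound 3 (0.04 log units; within the scatter), no larger than the scatter. On that basis compound 3 is expected to give about 2800 nM in this assay, with a likely range from 1400 nM to 5600 nM.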

Compound 3, concentration for 50% growth inhibition: 3580 nM
Beside the measured number, compound 3's estimate is 1.3-fold (0.11 log units) below it; the range from low to high includes it.
By their numbers in this assay, from the lowest: compounds 2, 1 and 3 (each within the scatter of the next).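

In this assay, going by these compounds alone, hydrogen in place of methoxy on an aromatic carbon, ortho to a methoxy group and meta to a large group, gives a first direct reading at this position (a 1.4-fold higher number from compound 2 to compound 3 (0.15 log units; within the scatter)). The related change, methoxy in place of hydrogen on an aromatic carbon, can now be read as well (a 1.2-fold higher number from compound 1 to compound 3 (0.06 log units; within the scatter)). Neither step separates its two compounds, so among the three compounds shown, a single methoxy group gained or lost on this ring leaves the numbers indistinguishable, and no one methoxy group stands out as mattering more than another. No other measurement is available here that could explain these steps.

The compounds shown carry only hydrogen or methoxy at these ring positions, so it remains open whether a hydroxyl group, a fluorine atom, an amine or a longer chain such as ethoxy would give a number beyond the scatter. On these data alone, the amine-bearing end of the shared core is also identical in all three compounds, so the effect of replacing that amine with, for example, an amide or a carboxylic acid remains unknown as well.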